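Trimming the Sulfonyl Side Chain of Compound 1

A few compounds are considered here, and "the series" means these few. Any claim that something is new, unique, unknown or untested is made for them only; others in the source may bear on it.

Measured compounds:
compound 1 `CC(C)C(=O)NCCS(=O)(=O)NC(=O)c1ccc(Nc2nc(NC3(c4ccc(Cl)cc4)CC3)nc(OCC(F)(F)F)n2)cc1` — 86%
compound 2 `CC(C)OC(=O)NCCS(=O)(=O)NC(=O)c1ccc(Nc2nc(NC3(c4ccc(Cl)cc4)CC3)nc(OCC(F)(F)F)n2)cc1` — 100%

In an ADME assay on microsomes from liver (Homo sapiens) for metabolic stability, with a stated time of 10 min (a lower number here means that less of the compound is left, a higher number that more of the compound is left), compound 1 gives 86%, the lower of the two numbers in hand. In this assay, for the measured compounds named here, compound 2 gives 100%, and the step of a number 14 percentage points higher from compound 1 to compound 2 (beyond the scatter) is the only measured comparison; it concerns the same side chain on the sulfonyl sulfur that is altered here. Compound 3 `CN(C)S(=O)(=O)NC(=O)c1ccc(Nc2nc(NC3(c4ccc(Cl)cc4)CC3)nc(OCC(F)(F)F)n2)cc1` differs from compound 1 as follows: dimethylamino in place of 2-((isopropylcarbonyl)amino)ethyl on a sulfonyl sulfur. Going by the values given here, no measured step removes this chain entirely, so the one step in hand bears on the new compound only loosely. Compound 1 already stands high in this assay, which leaves little room upward. Compound 3 is therefore expected to remain at a high level, with the step of a number 6 percentage points higher from compound 1 to compound 3 (within the scatter) estimated to be small. The estimate for compound 3 in this assay is 92%, with a range from 78% to 100%.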

Compound 3, percent of the compound remaining: 86%
Beside the measured number, compound 3's estimate is 6 percentage points above it; low and high end bracket the measured number.
By their numbers in this assay, from the lowest: compounds 1 and 3 (each within the scatter of the next); then compound 2.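

In this assay the 2-((isopropylcarbonyl)amino)ethyl chain on the sulfonyl sulfur can be exchanged for the much smaller dimethylamino with no change at the digits printed from compound 1 to compound 3 (within the scatter) and so, for this pair, the longer chain is not required to keep the read-out at the level of compound 1. The 2-((isopropoxycarbonyl)amino)ethyl chain alone stands apart, with a number 14 percentage points lower from compound 2 to compound 3 (beyond the scatter) and thus the gain seen with compound 2 does not carry over to dimethylamino. Nothing available explains either step.

The compounds shown leave open how a primary amine or a simple methyl group on the sulfonyl sulfur would read in this assay. They also leave open whether a longer chain ending in a carboxylic acid would stay at this level.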